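Working notes on a growth-inhibition series, compound 1 to compound 4

This account rests on a few compounds, and the source may have more. Where it says the series, first, only, none or still open, it means among the compounds named here.

Three compounds have numbers in a functional assay on HOP-62 cells (Homo sapiens) for inhibition, read by sulforhodamine B assay, with a stated time of 48 h; a lower number here means a stronger inhibitor of growth, a higher number a weaker inhibitor of growth. Compound 1, `Nc1cc(N)c2nc(-c3ccccc3)c(NCc3ccc(Cl)c(Cl)c3)nc2c1`, gives 15800 nM. Compound 2, `CCOC(=O)[C@H](CCC(=O)O)NC(=O)c1ccc(Sc2nc3cc(N)cc(N)c3nc2-c2ccccc2)cc1`, gives 15500 nM, which lies within the scatter of the number for compound 1. Compound 3, `CCOC(=O)[C@H](CCC(=O)O)NC(=O)c1ccc(Oc2nc3cc(N)cc(N)c3nc2-c2ccccc2)cc1`, gives 36300 nM, a higher number than compound 1 by more than the scatter. Compound 1 thus stands second highest of the three, at the same level as compound 2 and below compound 3. Among the measured compounds shown here, no two of these share a single point of difference, so no measured step is available.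

Compound 4, `Nc1cc(N)c2nc(-c3ccccc3)c(NCc3ccc(F)cc3)nc2c1`, is not yet measured. It differs from compound 1 in one place: 4-fluorophenyl in place of 3,4-dichlorophenyl on a saturated chain carbon bound to a nitrogen on an aromatic ring. For the measured compounds named here, no measured pair shows what this change does in this assay, so the expectation rests on compound 1 alone. A small step toward a higher number is expected, of about a 1.4-fold higher number from compound 1 to compound 4 (0.14 log units; within the scatter), not clearly beyond the scatter. Compound 4 is therefore estimated at 22000 nM, with a range from 9000 nM to 55000 nM.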

Compound 4, concentration for 50% growth inhibition: 38900 nM
The estimate for compound 4 lay 1.8-fold (0.25 log units) below the measured number; the measured number falls inside the stated range.
By their numbers in this assay, from the lowest: compounds 2 and 1 (each within the scatter of the next); then compounds 3 and 4 (each within the scatter of the next).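

Among the compounds shown here, this is the first measured single-place step: at the position on a saturated chain carbon bound to a nitrogen on an aromatic ring, 4-fluorophenyl in place of 3,4-dichlorophenyl gives a 2.5-fold higher number from compound 1 to compound 4 (0.39 log units; beyond the scatter) in this assay. The aryl group at this place therefore affects the number, although the step is modest and rests on a single pair. No measurement at hand bears on the reason for this shift.

For the compounds shown here, since the change alters the halogens in both kind and count, the single pair cannot separate their contributions, and it remains open where 4-chlorophenyl or unsubstituted phenyl would fall relative to compound 1 and compound 4. Also open, on these data alone, is how the number would respond at this place to a longer chain between the nitrogen and the ring, or to a carboxylic acid on the ring.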